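This account rests on a few compounds, and the source may have more. Where it says the series, first, only, none or still open, it means among the compounds named here.

Working notes on the series. In a functional assay on A549 cells (Homo sapiens) for cytotoxicity, read by MTT assay (a lower number here means a stronger inhibitor, a higher number a weaker inhibitor), compound 1 `CCOC(=O)c1oc2c(Br)c(OC)cc(OC)c2c1C` gives only a limit, > 87400 nM. Compound 2 `COc1cc(OC)c2c(C)c(C=O)oc2c1Br` carries the change (hydrogen in place of ethoxy on a carbonyl carbon), and in this assay compound 2 gives 49500 nM. The step is an at least 1.7-fold lower number from compound 1 to compound 2 (0.24 log units; that floor lies within the scatter); its floor follows from the limit of > 87400 nM in this assay, at which 1 of the 3 values shown sits. Compound 3 `CCOC(=O)c1oc2cc(OCc3ccccc3)cc(OCc3ccccc3)c2c1C` in this assay also gives only a limit, > 72000 nM, that is the limit of > 72000 nM in this assay, at which 1 of the 3 values shown sits. The difference between the core of compound 3 and the core of compound 1 is not broken down here. Compound 4 `Cc1c(C=O)oc2cc(OCc3ccccc3)cc(OCc3ccccc3)c12` differs from compound 3 by the same change, (hydrogen in place of ethoxy on a carbonyl carbon), at a place described in the same words. For compound 4 the expected step is an at least 1.3-fold lower number from compound 3 to compound 4 (0.11 log units; that floor lies within the scatter), resting on the measured at least 1.7-fold lower number from compound 1 to compound 2 (0.24 log units; that floor lies within the scatter) and on the limit of compound 3, > 72000 nM. The estimate for compound 4 in this assay is 55000 nM, between 25000 nM and 110000 nM, with a real chance that only a limit is reported.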

Compound 4, half-maximal inhibitory concentration: > 80600 nM
Compound 4 gave a limit, no number (the forecaster's own chance of this, stated with the estimate: 45%); at least 1.4-fold (0.16 log units) between middle value and limit.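

Compound 3 and compound 4 both give only limits, so the step between them cannot be read. The compounds shown leave open whether hydrogen in place of ethoxy on a carbonyl carbon changes the read-out on the core of compound 3.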